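The source may report more compounds than this note shows. Statements on the series, on what has been measured and on what is new or still open speak of the compounds shown alone.

Measured compounds:
compound 1 `CCCCCCCCCCCCCC[C@H]1N[C@@H](CO)[C@@H]1O`: 0.22 ug/mL
compound 2 `CCCCCCCCCCCCCC[C@H]1N[C@H](CO)[C@H]1O`: > 2 ug/mL
compound 3 `CCCCCCCCCCCCCC[C@@H]1N[C@@H](CO)[C@@H]1O`: 0.34 ug/mL

The three measured compounds share one skeleton and differ only in how their ring centres are arranged. In a functional assay on A549 cells (Homo sapiens) for cytotoxicity (on this read-out lower numbers stand for stronger inhibition and higher numbers for weaker inhibition), compound 1 gives 0.22 ug/mL. For compound 2 the result is a limit of this assay, > 2 ug/mL, not a number. Compound 3 gives 0.34 ug/mL, the highest of the two numbers; its nearest neighbour is compound 1, and the step of a 1.5-fold higher number from compound 1 to compound 3 (0.19 log units; within the scatter) stays within the scatter. The step of an at least 9.0-fold higher number from compound 1 to compound 2 (0.95 log units; beyond the scatter) and the step of an at least 5.8-fold lower number from compound 2 to compound 3 (0.76 log units; beyond the scatter) are larger, and these differences arise because the fact that compounds 1 and 2 differ only in the configuration as drawn and because of the fact that compounds 2 and 3 differ only in the configuration as drawn.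

Compound 4 `CC(C)CC[C@H](O)CCCCCCCCC[C@@H]1N[C@@H](CO)[C@@H]1O` carries a different change: 1-hydroxy-4-methylpentyl in place of pentyl on a saturated chain carbon, nine bonds along the chain from a saturated ring carbon. Among the measured compounds shown here, none of the measured steps alters the chain, so they do not bear on this change. With nothing to guide a direction, compound 4 is expected to stay near compound 3, the expected step being a 1.3-fold higher number from compound 3 to compound 4 (0.12 log units; within the scatter). The estimate for compound 4 is 0.45 ug/mL, with a range from 0.15 ug/mL to 1.5 ug/mL.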

Compound 4, half-maximal inhibitory concentration: > 2 ug/mL
Compound 4: a limit, no number (the forecaster's own chance of this, stated with the estimate: 15%); middle value at least 4.4-fold (0.64 log units) from the limit.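

Until now, only the arrangement of the ring centres had moved the read-out, but in this assay a change far out on the chain also counts: putting 1-hydroxy-4-methylpentyl in place of pentyl, nine bonds along the chain from a saturated ring carbon, gives an at least 5.8-fold higher number from compound 3 to compound 4 (0.76 log units; beyond the scatter). For compound 4 the result of > 2 ug/mL is a limit of this assay and not a number. The true size of the step therefore stays unknown, and only its lower bound can be read, because the result is a limit: the limit of > 2 ug/mL in this assay, at which 2 of the 4 values shown sit.

The compounds shown leave open whether the hydroxyl or the added methyl branch accounts for the loss, which a plain 1-hydroxypentyl or a 4-methylpentyl without the hydroxyl would separate. On these data alone, it also remains open how an amine or a carboxylic acid at this place on the chain would read, or the opposite configuration at the new hydroxyl carbon.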